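Fluoro for Isobutylcarbamoyl on the Indole-Bearing Core

The source may report more compounds than this note shows. Statements on the series, on what has been measured and on what is new or still open speak of the compounds shown alone.

Compound 1, `CCC1C(=O)N(C)c2cnc(-n3ccc4cc(C(N)=O)ccc43)nc2N1c1ccn(C)n1`: 31300 nM
Compound 2, `CCC1C(=O)N(C)c2cnc(Nc3ccc(S(=O)(=O)NCCCO)cc3)nc2N1c1ccn(C)n1`: 13400 nM
Compound 3, `CCC1C(=O)N(C)c2cnc(-n3ccc4cc(C(=O)NCC(C)C)ccc43)nc2N1c1ccn(C)n1`: 5600 nM

Of the compounds shown here, three sharing one core have been tested in a functional assay on K562 cells (Homo sapiens) for antiproliferative activity, read by CCK-8 assay, with a stated time of 72 h; on this read-out higher numbers stand for weaker inhibition of growth and lower numbers for stronger inhibition of growth. Compound 3 stands lowest of the three; compound 2 comes nearest, and compound 1 lies furthest away. For the measured compounds named here, the only single-point step measured so far, a 5.6-fold lower number from compound 1 to compound 3 (0.75 log units; beyond the scatter), shows that building out the amide-type nitrogen with isobutyl in place of hydrogen moved the number well beyond the scatter.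

Compound 4, `CCC1C(=O)N(C)c2cnc(-n3ccc4cc(F)ccc43)nc2N1c1ccn(C)n1`, has not yet been measured in this assay. It differs from compound 3 by fluoro in place of isobutylcarbamoyl on an aromatic carbon. Going by the values given here, no measured pair shows the whole isobutylcarbamoyl group being removed, so the step from compound 1 to compound 3 bears on it only indirectly: it shows that the amide-bearing position is sensitive, and that stripping the isobutyl portion alone cost a modest step. Taking away the entire group, leaving only fluoro, is expected to lose at least that much, so the number for compound 4 is expected to rise by a 3.9-fold higher number from compound 3 to compound 4 (0.59 log units; beyond the scatter). The estimate for compound 4 is 22000 nM, with a range from 6000 nM to 80000 nM.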

Compound 4, concentration for 50% growth inhibition: 6070 nM
For compound 4 the middle estimate is 3.6-fold (0.56 log units) above the measured one; the range from low to high includes it.
By their numbers in this assay, from the lowest: compounds 3 and 4 (each within the scatter of the next); then compound 2; then compound 1.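

The earlier step could be read as the isobutyl portion being what lowered the number, but in this assay the whole isobutylcarbamoyl group gives way to fluoro with a 1.1-fold higher number from compound 3 to compound 4 (0.04 log units; within the scatter), so an amide at this aromatic carbon is not needed to reach this level. The unsubstituted carbamoyl of compound 1 now stands apart from both other groups, as fluoro in place of carbamoyl gives a 5.2-fold lower number from compound 1 to compound 4 (0.71 log units; beyond the scatter), and among these three compounds the high number goes with that one group rather than with any loss of size. Nothing shown explains why these two very different groups land together.

The compounds leave open whether a bare hydrogen, chloro or methoxy at this carbon would sit with fluoro or with carbamoyl. They also leave open how an amine, a carboxylic acid or a longer chain on the amide nitrogen would read here.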